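Heading toward compound 4 from an unmeasured starting point

This account rests on a few compounds, and the source may have more. Where it says the series, first, only, none or still open, it means among the compounds named here.

The set rests on an ADME assay on microsomes from liver (Rattus norvegicus) for metabolic stability, read by LC-MS, with a stated time of 15 min, tested at 1 uM; on this read-out higher numbers stand for a more stable compound and lower numbers for a less stable compound. Among the measured compounds shown here, compound 1 `Cc1cc(F)cnc1N1CCN(C(=O)CCCc2cccc3ncc(CO)cc23)[C@@H](C)C1` gives 1% in this assay, and compound 2 `Cc1cc(F)cnc1N1CCN(C(=O)CCCc2cccc3ncccc23)[C@@H](C)C1` gives 0.2%; the step of a number 0.8 percentage points lower from compound 1 to compound 2 (within the scatter) is the only paired step with numbers, and it came with a hydrogen in place of hydroxymethyl on an aromatic carbon. Compound 3 `Cc1cncc(Cl)c1N1CCN(C(=O)CCS(=O)(=O)c2cccc3ncsc23)CC1` stands nowhere on the numbers: in this assay compound 3 gives "not determined" (no result reported), so there is no figure to place it against compound 1 or compound 2. Compound 4 `O=C(CCS(=O)(=O)c1cccc2ncsc12)N1CCN(c2ccncc2F)CC1` differs from compound 3 as follows: 3-fluoropyridin-4-yl in place of 3-chloro-5-methylpyridin-4-yl on an amine nitrogen in a ring. For the measured compounds named here, no measured step touches this change. Going by the values given here, the one step with numbers, from compound 1 to compound 2, concerns a different part of a different core and lies within the scatter, so it gives neither a direction nor a size for the move to compound 4 in this assay. Among the compounds with values here, what remains is that the only two compounds with numbers, compound 1 and compound 2, sit at the low end of the scale. Compound 4 is therefore expected to give about 8% in this assay, with a plausible range from 0.5% to 35%, and the estimate carries wide uncertainty.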

Compound 4, percent of the compound remaining: 29%
For compound 4 the middle estimate is 21 percentage points below the measured one, and the stated range covers the measured number.
By their numbers in this assay, from the lowest: compounds 2 and 1 (each within the scatter of the next); then compound 4.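

In this assay, among the compounds shown here, compound 3 gives "not determined" (no result reported) while compound 4 gives 29% and so no step between these two compounds can be read. The compounds shown leave open how 3-fluoropyridin-4-yl in place of 3-chloro-5-methylpyridin-4-yl changes this read-out. No available evidence bears on the result for compound 4.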